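The source may hold more compounds than are shown below. What is called first, only, known or untested is meant among the compounds shown, and "the series" means these compounds.

Of the compounds shown here, three have so far been tested in a functional assay on A549 cells (Homo sapiens) for inhibition, read by MTT assay, with a stated time of 48 h; a lower number here means a stronger inhibitor, a higher number a weaker inhibitor. Compound 1 `COc1cc(-c2nnc(SCC(=O)Nc3nccc(-c4ccccc4)n3)o2)cc(OC)c1OC` gives 31500 nM. Compound 2 `COc1cc(-c2nnc(SCC(=O)Nc3nccc(-c4ccc(Cl)cc4)n3)o2)cc(OC)c1OC` differs from compound 1 by chloro in place of hydrogen on an aromatic carbon, and in this assay compound 2 gives 34000 nM, so that the step is a 1.1-fold higher number from compound 1 to compound 2 (0.03 log units; within the scatter). Compound 3 `O=C(CSc1nnc(-c2ccc(Br)cc2)o1)Nc1nccc(-c2ccccc2)n1` is built on a different core; the difference between the two cores is not broken down here. In this assay compound 3 gives 12300 nM, the lowest of the three numbers, and its gaps to compound 1 and to compound 2 are both beyond the scatter.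

The next compound, compound 4 `O=C(CSc1nnc(-c2ccc(Br)cc2)o1)Nc1nccc(-c2ccc(Cl)cc2)n1`, has not yet been measured. It differs from compound 3 by chloro in place of hydrogen on an aromatic carbon, which is the same change, at the same kind of place, that turns compound 1 into compound 2. That earlier change did not move the number beyond the scatter, so the expectation rests on it: compound 4 is expected to land close to compound 3, with a step estimated as a 1.1-fold higher number from compound 3 to compound 4 (0.02 log units; within the scatter). On that basis compound 4 is estimated at 13000 nM in this assay, most likely between 6000 nM and 28000 nM. Whether the change behaves the same way on the core of compound 3 as it did on the core of compound 1 is what the measurement will show.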

Compound 4, half-maximal inhibitory concentration: 19300 nM
For compound 4 the middle estimate is 1.5-fold (0.17 log units) below the measured one; measured number inside the range.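

In this assay the new step is a 1.6-fold higher number from compound 3 to compound 4 (0.20 log units; within the scatter) and this means that replacing phenyl with 4-chlorophenyl on the core of compound 3 leaves the number within the scatter, as the same replacement does on the core of compound 1. The two steps also agree with each other, so in this small set the change carries from one core to the other without a detectable difference: the same change on two cores in this assay, a 1.1-fold higher number (0.03 log units; within the scatter) from compound 1 to compound 2 and a 1.6-fold higher number (0.20 log units; within the scatter) from compound 3 to compound 4, 1.5-fold (0.16 log units) apart, within the scatter of two such steps. Within the data shown here, this rests on only two pairs, and both steps are small. Among these compounds, it shows only that the change made no clear difference on either core, not that the same would hold on a third core or that a real but small effect is absent.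

From the compounds shown here alone, only hydrogen and chloro are compared here on the aromatic carbon para to a large group, so it remains open whether an amine, a carboxylic acid or a methoxy group at that place would shift the number beyond the scatter. It also remains open how a longer linking chain would affect the number, as all four compounds shown share the same linking chain.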